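A few compounds are considered here, and "the series" means these few. Any claim that something is new, unique, unknown or untested is made for them only; others in the source may bear on it.

Measured so far:
- compound 1 `CC(=O)c1ccc(NC(=O)Nc2cc(C)nc3ccccc23)cc1`: 19000 nM
- compound 2 `COc1ccc(NC(=O)Nc2cc(C)nc3ccccc23)cc1OC`: > 25000 nM

Among the measured compounds shown here, in an ADME assay on HepG2 cells (Homo sapiens) for cytotoxicity, with a stated time of 72 h (a higher number here means that more compound is needed for the effect, a lower number that less compound is needed), compound 1 gives 19000 nM, the only outright number among the values shown. Compound 2 is reported only as a limit of this assay, > 25000 nM, which is the limit of > 25000 nM in this assay, at which 1 of the 2 values shown sits. For the measured compounds named here, no step between measured compounds is available, so the size of any change must be estimated. Compound 3 `Cc1cc(NC(=O)Nc2ccc(SC(F)(F)F)cc2)c2ccccc2n1` differs from compound 1 in one place: (trifluoromethyl)sulfanyl in place of acetyl on an aromatic carbon. The expected step from compound 1 to compound 3 in this assay is a 1.6-fold lower number from compound 1 to compound 3 (0.20 log units; within the scatter), a modest move toward less compound being needed, not clearly beyond the scatter. For compound 3 the estimated value in this assay is 12000 nM, with a range from 4000 nM to 35000 nM.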

Compound 3, half-maximal effective concentration: 20000 nM
The estimate for compound 3 lay 1.7-fold (0.22 log units) below the measured number, and the stated range covers the measured number.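

In this assay, (trifluoromethyl)sulfanyl in place of acetyl on an aromatic carbon, para to a large group, gives a 1.1-fold higher number from compound 1 to compound 3 (0.02 log units; within the scatter). Among the compounds shown here, this is the first step between measured compounds that differ in one place, and it shows that this exchange at this position, with more heavy atoms entering than leaving, produces no difference beyond the scatter. Nothing measured here gives a reason for this outcome. As far as these compounds go, whether an amine or a carboxylic acid on the same aromatic carbon would stay within the scatter remains open, as does the effect of any change to the shared core.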